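4-(Trifluoromethyl)phenyl for cyclohexyl on the shared core

The source may report more compounds than this note shows. Statements on the series, on what has been measured and on what is new or still open speak of the compounds shown alone.

In a functional assay on MCF7 cells (Homo sapiens) for inhibition, read by sulforhodamine B assay (on this read-out lower numbers stand for stronger inhibition and higher numbers for weaker inhibition), compound 1 `Cc1ccc(NC2=CC(=O)c3c(nc4n3[C@H]3OC[C@@H](O)[C@H]3OC4)C2=O)cc1C` gives 4950 nM. Compound 2 `O=C1C=C(NC2CCCCC2)C(=O)c2c1nc1n2[C@H]2OC[C@@H](O)[C@H]2OC1` reads > 8000 nM, which is a limit and not a number. Compound 3 `O=C1C=C(Nc2ccc(C(F)(F)F)cc2)C(=O)c2c1nc1n2[C@H]2OC[C@@H](O)[C@H]2OC1` carries 4-(trifluoromethyl)phenyl in place of cyclohexyl on an amine nitrogen. For the measured compounds named here, no measured step in this assay covers this change. Going by the values given here, a modest gain in inhibition is expected, and the only number supporting that expectation is compound 1 at 4950 nM. The expected change is an at least 2.0-fold lower number from compound 2 to compound 3 (0.30 log units; that floor lies within the scatter). For compound 3 the estimate is 4000 nM, with an expected range of 1500 nM to 10000 nM.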

Compound 3, half-maximal inhibitory concentration: > 4000 nM
Compound 3 gave a limit, no number; the forecaster's own chance of this, stated with the estimate: 30%; the middle value lies on the limit itself.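

In this assay, for the compounds shown here, compound 2 and compound 3 both read as limits, and no step between them can be read. Going by these compounds, whether 4-(trifluoromethyl)phenyl in place of cyclohexyl on an amine nitrogen changes inhibition, and in which direction, stays open.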